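From Chloro to Methoxycarbonyl: Estimating Compound 3

A few compounds are considered here, and "the series" means these few. Any claim that something is new, unique, unknown or untested is made for them only; others in the source may bear on it.

Compound 1, `COc1ccc(S(=O)(=O)N2CCc3cccc(Nc4ccc(Cl)cc4)c32)cc1`: 1100 nM
Compound 2, `COc1ccc(S(=O)(=O)N2CCc3cccc(Nc4ccc(F)cc4)c32)cc1`: 557 nM

Of the compounds shown here, two have been measured in a functional assay on KB cells (Homo sapiens) for antiproliferative activity; on this read-out lower numbers stand for stronger inhibition and higher numbers for weaker inhibition. For the measured compounds named here, compound 1 gives 1100 nM, the highest of the two numbers, but the only other measurement sits close by, since a 2.0-fold lower number from compound 1 to compound 2 (0.30 log units; within the scatter). Compound 2 gives 557 nM.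

Compound 3, `COC(=O)c1ccc(Nc2cccc3c2N(S(=O)(=O)c2ccc(OC)cc2)CC3)cc1`, has not yet been measured. It differs from compound 1 in one place: methoxycarbonyl in place of chloro on an aromatic carbon. Going by the values given here, the single measured step, a 2.0-fold lower number from compound 1 to compound 2 (0.30 log units; within the scatter), exchanges one halogen for another and says little about putting a methoxycarbonyl group where a chloro group was. Among the compounds with values here, with no comparable step to lean on, nothing beyond the scatter is expected. For compound 3 the expected step is a 1.1-fold lower number from compound 1 to compound 3 (0.04 log units; within the scatter), essentially none. The estimate for compound 3 is therefore 1000 nM, with a range from 300 nM to 3500 nM to reflect the uncertainty of an untested kind of change.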

Compound 3, half-maximal inhibitory concentration: 93.5 nM
The estimate for compound 3 lay 11-fold (1.03 log units) above the measured number; the measured number lies below the stated range.
By their numbers in this assay, from the lowest: compound 3; then compounds 2 and 1 (each within the scatter of the next).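

Between the two halogens at this position, para to a large group, the numbers stayed within the scatter, so the earlier compounds gave no sign that the position responds to what is placed there. Methoxycarbonyl shows that it does: this assay records a 12-fold lower number from compound 1 to compound 3 (1.07 log units; beyond the scatter) and also a 6.0-fold lower number from compound 2 to compound 3 (0.78 log units; beyond the scatter) and both steps lie beyond the scatter, making compound 3 the lowest number of the three. The entering group has four heavy atoms and two hydrogen-bond acceptors where chloro has one heavy atom and no acceptors, but no measurement available here explains the drop.

On these data alone, it remains open whether the whole ester is needed, since a carboxylic acid, a primary amide or an acetyl group at the same place would test its parts separately. A longer ester such as ethoxycarbonyl would show whether the methyl end can grow.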